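Pyridin-4-yl to 3,4-dichlorophenyl in the series

The source may report more compounds than this note shows. Statements on the series, on what has been measured and on what is new or still open speak of the compounds shown alone.

In a functional assay on CCRF-CEM cells (Homo sapiens) for antiproliferative activity (on this read-out lower numbers stand for stronger inhibition and higher numbers for weaker inhibition), compound 1 (`COc1cc(C(=O)c2sc(-c3ccc(Br)cc3)cc2N)cc(OC)c1OC`) gives 86 nM, compound 2 (`COc1cc(C(=O)c2sc(-c3ccc([N+](=O)[O-])cc3)cc2N)cc(OC)c1OC`) gives 99 nM and compound 3 (`COc1cc(C(=O)c2sc(-c3ccncc3)cc2N)cc(OC)c1OC`) gives 110 nM. Compound 3 thus stands within the scatter of both others. Compound 4 (`COc1cc(C(=O)c2sc(-c3ccc(Cl)c(Cl)c3)cc2N)cc(OC)c1OC`) has 3,4-dichlorophenyl in place of pyridin-4-yl on an aromatic carbon, next to the ring sulfur: 3,4-dichlorophenyl in place of pyridin-4-yl on an aromatic carbon. Three measured swaps at this place bear on the change: a 1.2-fold higher number from compound 1 to compound 2 (0.06 log units; within the scatter), a 1.3-fold higher number from compound 1 to compound 3 (0.11 log units; within the scatter) and a 1.1-fold higher number from compound 2 to compound 3 (0.05 log units; within the scatter). All three lie within the scatter, so no step beyond the scatter is expected in this assay. The expected step is a 1.2-fold lower number from compound 3 to compound 4 (0.09 log units; within the scatter). The estimate for compound 4 is 90 nM, with an expected range of 35 nM to 230 nM.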

Compound 4, half-maximal inhibitory concentration: 290 nM
The estimate for compound 4 lay 3.2-fold (0.51 log units) below the measured number, outside the stated range (above it).
By their numbers in this assay, from the lowest: compounds 1, 2 and 3 (each within the scatter of the next); then compound 4.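

In this assay, the aryl group at this position, next to the ring sulfur, now makes a difference: 3,4-dichlorophenyl gives a 2.6-fold higher number from compound 3 to compound 4 (0.42 log units; beyond the scatter) and a 2.9-fold higher number from compound 2 to compound 4 (0.47 log units; beyond the scatter) and a 3.4-fold higher number from compound 1 to compound 4 (0.53 log units; beyond the scatter) with all three steps beyond the scatter, whereas 4-bromophenyl, 4-nitrophenyl and pyridin-4-yl stay within the scatter of one another. The position therefore does not treat every aryl group alike. No measured data bear on why this step occurs. Open, going by these compounds, is whether the loss needs both chlorines, which 4-chlorophenyl and 3-chlorophenyl would separate. Also open, on these data alone, is how a non-aromatic group such as morpholine or a longer alkyl chain would fare here.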